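3-methylbenzyl to 4-chlorobenzyl

The compounds below may be only part of what the source reports. "The series", "measured", "known", "first", "only" and "open" are said of these compounds alone.

Measured in a functional assay on HepG2 cells (Homo sapiens) for inhibition, read by MTT assay, with a stated time of 72 h; a lower number here means a stronger inhibitor, a higher number a weaker inhibitor:
- Compound 1 `Cc1ccc(CN2CCc3ncn(COCc4ccccc4)c3/C(=C/c3ccccc3)C2=O)cc1`: 44700 nM
- Compound 2 `Cc1cccc(CN2CCc3ncn(COCc4ccccc4)c3/C(=C/c3ccccc3)C2=O)c1`: 34300 nM

Among the compounds with values here, on these numbers, compound 2 stands level with its one measured neighbour. The next structure, compound 3 `O=C1/C(=C\c2ccccc2)c2c(ncn2COCc2ccccc2)CCN1Cc1ccc(Cl)cc1`, alters the same group: 4-chlorophenyl in place of 3-methylphenyl on a saturated chain carbon bound to an amide-type nitrogen in a ring. Within the data shown here, the only measured step at this place swapped 4-methylphenyl for 3-methylphenyl, and it stayed small: a 1.3-fold lower number from compound 1 to compound 2 (0.12 log units; within the scatter). Among the measured compounds shown here, no compound carrying 4-chlorophenyl has a measured value yet, so this one step is a thin guide. The expected change is none beyond the scatter in this assay, namely a 1.0-fold higher number from compound 2 to compound 3 (0.02 log units; within the scatter). For compound 3 the estimate is 36000 nM, with an expected range from 16000 nM to 75000 nM.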

Compound 3, half-maximal inhibitory concentration: 47900 nM
Beside the measured number, compound 3's estimate is 1.3-fold (0.12 log units) below it; the range from low to high includes it.
By their numbers in this assay, from the lowest: compounds 2, 1 and 3 (each within the scatter of the next).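

In this assay, 4-chlorophenyl in place of 3-methylphenyl gives a 1.4-fold higher number from compound 2 to compound 3 (0.15 log units; within the scatter), so a different substituent on this ring, not just a moved methyl, also stays within the scatter. Chloro in place of methyl on an aromatic carbon gives a 1.1-fold higher number from compound 1 to compound 3 (0.03 log units; within the scatter), so all three compounds read alike so far. No supporting evidence is available to explain this flat result. Still open, going by these compounds, is whether an amine or a carboxylic acid on this ring would change the number. A longer chain in place of the benzyl carbon is equally untested here.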